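This account rests on a few compounds, and the source may have more. Where it says the series, first, only, none or still open, it means among the compounds named here.

In a functional assay on MCF7 cells (Homo sapiens) for antiproliferative activity, read by sulforhodamine B assay, with a stated time of 72 h (a lower number here means a stronger inhibitor, a higher number a weaker inhibitor), compound 1 `COc1cc2occ(-c3csc4ccccc34)c(=O)c2cc1OC` gives only a limit of > 10000 nM. Compound 2 `COc1c(OC(C)C)cc2oc(-n3cncn3)c(-c3csc4ccccc34)c(=O)c2c1OC(C)C` also gives only a limit, > 10000 nM. Within the data shown here, compound 3 `O=C(/C=C/c1csc2ccccc12)c1ccccc1O` is the one compound of these three with an actual number, 6600 nM, so it is the natural starting point. Compound 4 `O=C(/C=C/c1csc2ccccc12)c1cc(Br)ccc1O` differs from compound 3 in one place: bromo in place of hydrogen on an aromatic carbon. This is bromo in place of hydrogen on an aromatic carbon, para to a hydroxy group. Among the measured compounds shown here, no measured pair of compounds shows what such a change does, so only a modest move toward stronger inhibition is expected, and it may stay within the scatter. The expected size of the change is a 1.9-fold lower number from compound 3 to compound 4 (0.28 log units; within the scatter). For compound 4 the estimated value is 3500 nM, with an expected range from 1000 nM to 10000 nM.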

Compound 4, half-maximal inhibitory concentration: 1040 nM
Estimate against measurement, compound 4: 3.4-fold (0.53 log units) above; the range from low to high includes it.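

In this assay, bromo in place of hydrogen on an aromatic carbon, para to a hydroxy group, gives a 6.3-fold lower number from compound 3 to compound 4 (0.80 log units; beyond the scatter). Among these compounds, this is the one step here that can be read, and it shows that this position accepts a bromine atom and that inhibition grows stronger with it. Compounds 1 and 2 offer no such reading, as each gives only a limit: the limit of > 10000 nM in this assay, at which 2 of the 4 values shown sit.

From the compounds shown here alone, only bromo appears at this position, so whether chloro, methoxy or an amine would do the same stays open. Going by these compounds, whether the hydroxy group is needed for this step also stays open.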